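A Sugar Replaces the Acetonide on the Triazole

The source may hold more compounds than are shown below. What is called first, only, known or untested is meant among the compounds shown, and "the series" means these compounds.

Compound 3 `CC1(C)OC[C@@H](Cn2cc(Cn3c4c(c5ccccc53)C(=O)c3c[n+]([O-])c5ccccc5c3C4=O)nn2)O1` carries a 2,2-dimethyl-1,3-dioxolan-4-yl group. In a functional assay on MDA-MB-231 cells (Homo sapiens) for cytotoxicity, read by MTT assay, with a stated time of 72 h (a lower number here means a stronger inhibitor, a higher number a weaker inhibitor), compound 3 gives only a limit, > 1000 nM. Compound 1 `O=C1c2c[n+]([O-])c3ccccc3c2C(=O)c2c1c1ccccc1n2Cc1cn(C[C@@H](O)CO)nn1`, bearing 1,2-dihydroxyethyl, gives 670 nM in this assay, and compound 2 `CC1(C)OCC(Cn2cc(Cn3c4c(c5ccccc53)C(=O)c3c[n+]([O-])c5ccccc5c3C4=O)nn2)O1` gives 230 nM. The measured comparisons that bear on the next step are an at least 1.4-fold higher number from compound 1 to compound 3 (0.17 log units; that floor lies within the scatter) and an at least 4.3-fold higher number from compound 2 to compound 3 (0.63 log units; beyond the scatter), with the limit of > 1000 nM in this assay, at which 1 of the 3 values shown sits, and the fact that one of compounds 2 and 3 is drawn with a defined configuration and the other without, at the place where they differ standing behind them. Compound 4 `O=C1c2c[n+]([O-])c3ccccc3c2C(=O)c2c1c1ccccc1n2Cc1cn([C@@H]2O[C@H](CO)[C@@H](O)[C@H](O)[C@H]2O)nn1` differs from compound 3 by 3,4,5-trihydroxy-6-(hydroxymethyl)oxan-2-yl in place of (2,2-dimethyl-1,3-dioxolan-4-yl)methyl on an aromatic nitrogen. Since compound 1 with 1,2-dihydroxyethyl gave 670 nM, a result near that range or weaker is expected for compound 4. The step that the limit leaves unreadable from compound 3 to compound 4 is expected to be small, likely none beyond the scatter. Compound 4 is estimated at 1200 nM, within 400 nM to 4000 nM.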

Compound 4, half-maximal inhibitory concentration: 650 nM
Compound 4: the middle estimate sits 1.8-fold (0.27 log units) above what was measured; measured number inside the range.
By their numbers in this assay, from the lowest: compound 2; then compounds 4 and 1 (each within the scatter of the next). At a limit, above all of these: compound 3.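

At this aromatic nitrogen, 3,4,5-trihydroxy-6-(hydroxymethyl)oxan-2-yl and 2,3-dihydroxypropyl cannot be told apart in this assay: the change gives a 1.0-fold lower number from compound 1 to compound 4 (0.01 log units; within the scatter). The same oxane group does not match the (2,2-dimethyl-1,3-dioxolan-4-yl)methyl group drawn without a configuration, with a 2.8-fold higher number from compound 2 to compound 4 (0.45 log units; beyond the scatter). Compound 3 gives only a limit, > 1000 nM. Measured against that limit, the change to the oxane group gives an at least 1.5-fold lower number from compound 3 to compound 4 (0.18 log units; that floor lies within the scatter). From the compounds shown here alone, what an amine or a carboxylic acid at this nitrogen would give stays open, and so does the effect of a longer chain between this nitrogen and the oxane ring.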